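Removing the fluoro from compound 1: what to expect

The source may report more compounds than this note shows. Statements on the series, on what has been measured and on what is new or still open speak of the compounds shown alone.

Measured so far in an assay on MDA-MB-231 cells for binding affinity to C-X-C chemokine receptor type 4 (Homo sapiens), read by immunofluorescence and microscopy, with stated times of 10 min and 30 min; a lower number here means that less compound is needed, a higher number that more compound is needed for the effect:
compound 1 `O=C(NCc1ccc(CNS(=O)(=O)c2ccccc2)cc1)c1cccc(F)c1` gives 100 nM;
compound 2 `COc1cccc(C(=O)NCc2ccc(CNS(=O)(=O)c3ccc(C)cc3)cc2)c1` gives 10 nM;
compound 3 `Cc1ccc(S(=O)(=O)NCc2ccc(CNC(=O)c3ccncc3)cc2)cc1` gives 10 nM.

Among these three, compound 1 stands with the highest number, the other two sharing a lower number, a gap beyond the scatter in both cases. Compound 4 `O=C(NCc1ccc(CNS(=O)(=O)c2ccccc2)cc1)c1ccccc1` differs from compound 1 in one place: hydrogen in place of fluoro on an aromatic carbon. Put another way, 3-fluorophenyl gives way to phenyl on the carbonyl carbon.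

Among the compounds with values here, no measured step concerns a fluoro. Within the data shown here, the only step available, no change at the digits printed from compound 2 to compound 3 (within the scatter), exchanges the whole aryl group on the carbonyl carbon and moves the number not at all within the scatter, suggesting this part of the shared core tolerates variation, though it is read on a core bearing a methylphenyl sulfonyl rather than the phenyl sulfonyl of compound 1. Compound 1 therefore offers no direct guide to its own fluoro, and the expected step of no change at the digits printed from compound 1 to compound 4 (within the scatter) is none beyond the scatter. Compound 4 is estimated at 100 nM, within 30 nM to 300 nM.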

Compound 4, effective concentration (reported as EC, without a stated level of effect): 1 nM
Estimate against measurement, compound 4: 100-fold (2.00 log units) above; the measured number lies below the stated range.
By their numbers in this assay, from the lowest: compound 4; then compounds 2 and 3 (each within the scatter of the next); then compound 1.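

In this assay, the single replacement of fluoro by hydrogen gives a 100-fold lower number from compound 1 to compound 4 (2.00 log units; beyond the scatter), so on the core of compound 1 one heavy atom on this aromatic carbon separates two clearly different numbers. The earlier step, no change at the digits printed from compound 2 to compound 3 (within the scatter), exchanged a whole aryl group on a core with a different sulfonyl group and gave no sign that so small a change at the carbonyl end could matter this much. Nothing measured here accounts for the size of this step.

The compounds shown leave open whether the higher number belongs to fluoro specifically or would also follow from a chloro or an amine on the same aromatic carbon. They also leave open whether removing a fluoro would have a similar effect on the core carrying the methylphenyl sulfonyl group.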